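A Larger Group on the Carbonyl of a Weak Compound

This account rests on a few compounds, and the source may have more. Where it says the series, first, only, none or still open, it means among the compounds named here.

Compound 1 `O=C(CCl)Nc1ccc(-c2nc3ccccc3s2)cc1` gives only a limit in a functional assay on MDA-MB-468 cells (Homo sapiens) for antiproliferative activity (a lower number here means a stronger inhibitor, a higher number a weaker inhibitor), where the half-maximal inhibitory concentration of compound 1 is reported as > 100 nM and not as a number. Its iodo relative, compound 2 `O=C(CCl)Nc1ccc(-c2nc3ccccc3s2)cc1I`, also gives only a limit, with compound 2 at > 10 nM in this assay as the reported result. For the measured compounds named here, the one measured change is a step that the two limits leave unreadable from compound 1 to compound 2 and so offers no size to carry forward. That change also lies elsewhere in the molecule, on an aromatic carbon.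

Compound 3 `O=C(Nc1ccc(-c2nc3ccccc3s2)cc1)c1ccccc1` differs from compound 1 at the carbonyl carbon: phenyl in place of chloromethyl on a carbonyl carbon is the full change, with phenyl in place of chloromethyl. Going by the values given here, no measured step covers this swap, so neither its size nor its direction can be read from the data. The expectation therefore rests on compound 1 at > 100 nM as its only anchor, and it stays weak and wide.

For compound 3 the expected value is 2000 nM in this assay, with an estimated range of 100 nM to 30000 nM around it. This estimate means an expected step that the limit leaves unreadable from compound 1 to compound 3 on the numbers available.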

Compound 3, half-maximal inhibitory concentration: > 1000 nM
Compound 3 gave a limit, no number; the forecaster's own chance of this, stated with the estimate: 55%; the middle value does not contradict the limit.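

In this assay compound 3 gives only a limit, > 1000 nM. Compound 1 also gives only a limit, > 100 nM. Together these limits leave the change from compound 1 to compound 3 unreadable in both size and direction. Still open, going by these compounds, is whether phenyl or chloromethyl on the carbonyl carbon gives the stronger inhibitor.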